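The source may report more compounds than this note shows. Statements on the series, on what has been measured and on what is new or still open speak of the compounds shown alone.

Measured compounds:
compound 1, `C/C=C/C(=O)Nc1cc2c(N3CCc4ccccc43)ncnc2cc1OC`, 8120 nM;
compound 2, `C/C=C/C(=O)Nc1cc2c(N3CCc4ccccc43)ncnc2cc1O[C@@H]1CCOC1`, 5220 nM;
compound 3, `C/C=C/C(=O)Nc1cc2c(N3CCCc4ccccc43)ncnc2cc1O[C@@H]1CCOC1`, 9350 nM.

All three were tested in a functional assay on PC-3 cells (Homo sapiens) for antiproliferative activity, read by MTT assay, with a stated time of 72 h; on this read-out higher numbers stand for weaker inhibition and lower numbers for stronger inhibition. Compound 1 gives the second highest of the three numbers; its distance to compound 3 and to compound 2 both lie within the scatter, so the three compounds cannot be told apart on this read-out. The two measured steps, a 1.6-fold lower number from compound 1 to compound 2 (0.19 log units; within the scatter) and a 1.8-fold higher number from compound 2 to compound 3 (0.25 log units; within the scatter), also stay within the scatter.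

Compound 4, `CCN(CC)C/C=C/C(=O)Nc1cc2c(N3CCc4ccccc43)ncnc2cc1OC`, differs from compound 1 by diethylamino in place of hydrogen on a saturated chain carbon bound to a double-bonded chain carbon. Neither measured step touches this part of the molecule: one changes the group on the aromatic oxygen, the other the ring attached to the shared core. Going by the values given here, no measured step therefore bears on the change to compound 4, and no step beyond the scatter is expected in this assay. The expected value for compound 4 is 5500 nM, with a range of 1500 nM to 16000 nM, which means an expected step of a 1.5-fold lower number from compound 1 to compound 4 (0.17 log units; within the scatter).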

Compound 4, half-maximal inhibitory concentration: 3690 nM
Estimate against measurement, compound 4: 1.5-fold (0.17 log units) above, and the stated range covers the measured number.
By their numbers in this assay, from the lowest: compounds 4, 2, 1 and 3 (each within the scatter of the next, the first and the last beyond it).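

In this assay, diethylamino in place of hydrogen on a saturated chain carbon bound to a double-bonded chain carbon gives a 2.2-fold lower number from compound 1 to compound 4 (0.34 log units; beyond the scatter), the only step shown that lies beyond the scatter, though modestly. This position, untouched by the two earlier steps, therefore accepts a group of 5 heavy atoms, and the number falls rather than rises. Nothing available explains this fall.

Going by these compounds, whether the fall belongs to diethylamino in particular stays open, since dimethylamino, a morpholine ring or a longer chain on the same carbon could give a different number. Also open, on these data alone, is whether diethylamino at this position would give a similar step on compound 2 or compound 3, which carry oxolan-3-yl on the aromatic oxygen.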